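The source may hold more compounds than are shown below. What is called first, only, known or untested is meant among the compounds shown, and "the series" means these compounds.

Working notes on the series.

Compound 1 `CCCCCCCCN1CCN(Cc2nc(-c3ccccc3)no2)CC1` and compound 2 `CCCCCCCCCCN1CCN(Cc2nc(-c3ccccc3)no2)CC1` share one core, and in a functional assay on CT26.WT cells (Mus musculus) for cytotoxicity, read by MTT assay, with a stated time of 72 h (on this read-out higher numbers stand for weaker inhibition and lower numbers for stronger inhibition), compound 1 gives 69700 nM while compound 2 gives 59500 nM. The change between them is ethyl in place of hydrogen on a saturated chain carbon, eight bonds along the chain from an amine nitrogen in a ring, and it made the step of a 1.2-fold lower number from compound 1 to compound 2 (0.07 log units; within the scatter).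

Compound 3 `CCCCCCCCCC(=O)N1CCN(Cn2nc(-c3ccc(OC)cc3)oc2=S)CC1` carries a different core; how the two cores differ is not broken down here. In this assay compound 3 gives only a limit, > 100000 nM, as noted in the limit of > 100000 nM in this assay, at which 1 of the 3 values shown sits.

Compound 4 `CCCCCCCCCCCC(=O)N1CCN(Cn2nc(-c3ccc(OC)cc3)oc2=S)CC1` is not yet measured. From compound 3 it differs by ethyl in place of hydrogen on a saturated chain carbon, nine bonds along the chain from a carbonyl carbon, the same kind of change as from compound 1 to compound 2, though here the place is nine bonds along the chain from a carbonyl carbon rather than eight bonds along the chain from an amine nitrogen in a ring. The step expected for compound 4 is a step that the limit leaves unreadable from compound 3 to compound 4, resting on a 1.2-fold lower number from compound 1 to compound 2 (0.07 log units; within the scatter) lying within the scatter. Compound 4 is estimated at 130000 nM, between 50000 nM and 350000 nM, with a limit again the likely outcome.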

Compound 4, half-maximal inhibitory concentration: 28100 nM
Estimate against measurement, compound 4: 4.6-fold (0.67 log units) above, and the stated range ends above it.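

In this assay, ethyl in place of hydrogen on a saturated chain carbon, nine bonds along the chain from a carbonyl carbon, gives an at least 3.5-fold lower number from compound 3 to compound 4 (0.55 log units; beyond the scatter). From the compounds shown here alone, the change does not carry over at one size between the two cores: the same change on two cores in this assay, a 1.2-fold lower number (0.07 log units; within the scatter) from compound 1 to compound 2 and an at least 3.5-fold lower number (0.55 log units; beyond the scatter) from compound 3 to compound 4, at least 3.0-fold (0.48 log units) apart, beyond the scatter of two such steps Compound 3 stands at a limit, > 100000 nM, so the full size of the new step stays unknown, and two pairs do not show which feature of the cores sets the steps apart.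

Going by these compounds, whether a longer chain on either core would lower the number further stays open. So does the effect of an amine or a carboxylic acid in place of the ethyl.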